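Aryl group on the sulfonyl sulfur: notes toward compound 4

The source may hold more compounds than are shown below. What is called first, only, known or untested is meant among the compounds shown, and "the series" means these compounds.

Measured so far in an assay on MDA-MB-231 cells for binding affinity to C-X-C chemokine receptor type 4 (Homo sapiens), read by fluorescence and microscopy, with stated times of 10 min and 30 min; a lower number here means that less compound is needed, a higher number that more compound is needed for the effect:
compound 1, `O=C(NCc1ccc(CNS(=O)(=O)c2ccc3c(c2)CCO3)cc1)c1ccc(F)cc1`: compound 1 gives 10 nM
compound 2, `O=C(NCc1ccc(CNS(=O)(=O)c2cccc3ccccc23)cc1)c1ccc(F)cc1`: compound 2 gives 1000 nM
compound 3, `O=C(NCc1ccc(CNS(=O)(=O)c2ccccc2Cl)cc1)c1ccc(F)cc1`: compound 3 gives 1000 nM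

Compound 1 holds the lowest of the three numbers in this assay. Its nearest neighbour is compound 2, reached by a 100-fold higher number from compound 1 to compound 2 (2.00 log units; beyond the scatter); compound 3 lies equally far, reached by a 100-fold higher number from compound 1 to compound 3 (2.00 log units; beyond the scatter). Between the two weaker members the difference is no change at the digits printed from compound 2 to compound 3 (within the scatter).

Compound 4, `Cc1cccc(S(=O)(=O)NCc2ccc(CNC(=O)c3ccc(F)cc3)cc2)c1`, differs from compound 1 by a group of 7 heavy atoms (7 carbon; one six-membered aromatic ring of carbon only) in place of a group of 9 heavy atoms (8 carbon, 1 oxygen; one five-membered non-aromatic ring with 1 hetero atom, one six-membered aromatic ring of carbon only), on a sulfonyl sulfur. Both measured steps that leave compound 1 exchange the group on the sulfonyl sulfur for a different aromatic group, and both are large in the same direction. Within the data shown here, the change to compound 4 is of the same kind, so a step of comparable size is expected rather than none; the two measured exchanges give no example of a small loss, and 3-methylphenyl has no nearer measured relative than 2-chlorophenyl or naphthalen-1-yl.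

The expected step is a 50-fold higher number from compound 1 to compound 4 (1.70 log units; beyond the scatter). Compound 4 is estimated at 500 nM, with a range from 100 nM to 3000 nM.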

Compound 4, effective concentration (reported as EC, without a stated level of effect): 1 nM
Compound 4: middle estimate off by 500-fold (2.70 log units), on the high side; the whole stated range lies above it.
By their numbers in this assay, from the lowest: compound 4; then compound 1; then compounds 2 and 3 (each within the scatter of the next).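

In this assay the group on the sulfonyl sulfur can improve on compound 1 as well as lose to it: 3-methylphenyl gives a 10-fold lower number from compound 1 to compound 4 (1.00 log units; beyond the scatter) and so shows that the five-membered non-aromatic ring of compound 1 is not required for a low number. Against the two weaker members, the same group gives a 1000-fold lower number from compound 3 to compound 4 (3.00 log units; beyond the scatter) and a 1000-fold lower number from compound 2 to compound 4 (3.00 log units; beyond the scatter) at this one position. Absence of that ring does not by itself give a low number, as compound 2 and compound 3 also lack it and remain high, so the identity of the aromatic group matters here.

Going by these compounds, how phenyl or 3-methoxyphenyl on the sulfonyl sulfur would compare with 3-methylphenyl remains open, and with it the part played by the methyl group itself. Nothing at hand bears on the reason for these steps.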